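A few compounds are considered here, and "the series" means these few. Any claim that something is new, unique, unknown or untested is made for them only; others in the source may bear on it.

Measured compounds:
Compound 1, `Cc1cc(C)c(CN2CCc3c(Cl)cc([C@@H](CO)[C@@H]4CCCO4)c(Cl)c3C2=O)c(=O)[nH]1`, gives 1570 nM in an assay on cells for inhibition of histone-lysine N-methyltransferase EZH2 (Homo sapiens), read by ELISA, with a stated time of 72 h; on this read-out higher numbers stand for weaker inhibition and lower numbers for stronger inhibition.
Compound 2, `COc1cc(C)[nH]c(=O)c1CN1CCc2c(Cl)cc([C@H](O)C3COC3)c(Cl)c2C1=O`, gives 99 nM in this assay.

Of the two measured compounds, compound 1 carries the higher number; compound 2 sits well below it, by a margin beyond the usual scatter, so the two values show compound 2 as the stronger inhibitor in this assay. The pair differs in several places at once, so nothing about any single change can be drawn from it.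

Compound 3, `Cc1cc(C)c(CN2CCc3c(Cl)cc([C@H](C)CO)c(Cl)c3C2=O)c(=O)[nH]1`, has not yet been measured. It differs from compound 1 in one place: methyl in place of oxolan-2-yl on a saturated chain carbon bound to an aromatic carbon and a saturated chain carbon. The oxolan-2-yl group of compound 1, with its one hydrogen-bond acceptor and its defined stereocentre, is removed and a methyl takes its place, leaving the hydroxymethyl arm and the rest of the shared core untouched.

Among the compounds with values here, no measured pair shows this change, so the expectation rests on compound 1 alone. The step of a 1.0-fold lower number from compound 1 to compound 3 (0.02 log units; within the scatter) is expected to stay within the scatter, in either direction. Compound 3 is estimated at 1500 nM, in a range from 500 nM to 5000 nM.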

Compound 3, half-maximal inhibitory concentration: 129 nM
Estimate against measurement, compound 3: 12-fold (1.07 log units) above, outside the stated range (below it).
By their numbers in this assay, from the lowest: compounds 2 and 3 (each within the scatter of the next); then compound 1.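

Putting methyl in place of oxolan-2-yl on this saturated chain carbon, bound to an aromatic carbon and a saturated chain carbon, gives a 12-fold lower number from compound 1 to compound 3 (1.09 log units; beyond the scatter) in this assay and is the first change at a single place among these compounds. It shows that the group at this position has a large bearing on the read-out, which the earlier pair, differing in several places at once, could not show. In this pair, the five-membered ring with its hydrogen-bond acceptor and defined stereocentre is not needed for inhibition, since the single carbon that replaces it gives the stronger inhibitor; no measurement at hand accounts for the size of this step.

From the compounds shown here alone, it remains open whether ethyl or cyclopentyl at this carbon, the latter keeping a five-membered ring made of carbon alone, would read like methyl or like oxolan-2-yl. Also open, going by these compounds, is how an amine or a carboxylic acid would read in place of the hydroxymethyl arm, which this step left untouched.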